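Swapping ethoxy for trifluoroethyl on the shared core

This account rests on a few compounds, and the source may have more. Where it says the series, first, only, none or still open, it means among the compounds named here.

Compound 3 `CCOc1ccc(C(=O)NCc2ccc(NS(C)(=O)=O)cc2Cl)cc1` gives 2200 nM in an assay on HeLa cells for agonist activity at Bile acid receptor (Homo sapiens), read by a luciferase reporter, with a stated time of 24 h (a lower number here means that less compound is needed, a higher number that more compound is needed for the effect), the highest of the three numbers measured; compound 1 `CS(=O)(=O)Nc1ccc(CNC(=O)c2ccc(C3(C(F)(F)F)CC3)cc2)c(Cl)c1` gives 540 nM and compound 2 `CS(=O)(=O)Nc1ccc(CNC(=O)c2ccc(N3CCCCC3)cc2)c(Cl)c1` gives 410 nM in this assay. The step of a 4.1-fold higher number from compound 1 to compound 3 (0.61 log units; beyond the scatter) and the step of a 5.4-fold higher number from compound 2 to compound 3 (0.73 log units; beyond the scatter) both end at compound 3, so putting ethoxy in place of either group raised the number beyond the scatter, whereas the step of a 1.3-fold lower number from compound 1 to compound 2 (0.12 log units; within the scatter) stays within it. Compound 4 `CS(=O)(=O)Nc1ccc(CNC(=O)c2ccc(CC(F)(F)F)cc2)c(Cl)c1` has not yet been measured in this assay. It differs from compound 3 in one place: 2,2,2-trifluoroethyl in place of ethoxy on an aromatic carbon. Among the measured compounds shown here, no measured step covers this exact group, but the two steps that end at ethoxy both point the same way, and compound 4 carries three fluorines as compound 1 does. For compound 4 the expected step back toward lower numbers is therefore a 2.4-fold lower number from compound 3 to compound 4 (0.39 log units; beyond the scatter). The size of that expected step is uncertain. For compound 4 the estimate is 900 nM, with a range from 350 nM to 2500 nM.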

Compound 4, half-maximal effective concentration: 4000 nM
Compound 4: the middle estimate sits 4.4-fold (0.65 log units) below what was measured, outside the stated range (above it).
By their numbers in this assay, from the lowest: compounds 2 and 1 (each within the scatter of the next); then compounds 3 and 4 (each within the scatter of the next).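

In this assay, a 1.8-fold higher number from compound 3 to compound 4 (0.26 log units; within the scatter) stays within the scatter, so at this position, para to a large group, 2,2,2-trifluoroethyl and ethoxy cannot be told apart, and carrying three fluorines does not by itself place a compound with compound 1. Instead, a 7.4-fold higher number from compound 1 to compound 4 (0.87 log units; beyond the scatter) and a 9.8-fold higher number from compound 2 to compound 4 (0.99 log units; beyond the scatter) are both beyond the scatter, so across these four compounds, with none going against it, the two groups containing a ring give lower numbers than the two open chains. Nothing available gives a reason for this split.

Still open, on these data alone, is whether the ring itself matters or only the size of the group. A diethylamino group or a longer chain such as butoxy would test the first, and a plain cyclopropyl or a morpholine ring would show how much the ring tolerates change.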